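This account rests on a few compounds, and the source may have more. Where it says the series, first, only, none or still open, it means among the compounds named here.

Measured so far, in a functional assay on Jurkat cells (Homo sapiens) for antiproliferative activity, read by MTT assay, with a stated time of 72 h; on this read-out higher numbers stand for weaker inhibition and lower numbers for stronger inhibition:

- compound 1, `C=C(Br)C(=O)Nc1ccc2c(c1)/C(=C\c1cccs1)C(=O)N2`: 616 nM
- compound 2, `C=C(Br)C(=O)Nc1ccc2c(c1)/C(=C\c1ccsc1)C(=O)N2`: 56 nM
- compound 3, `C=C(Br)C(=O)Nc1ccc2c(c1)/C(=C\c1sccc1C)C(=O)N2`: 340 nM

Compound 2 gives the lowest number of the three in this assay. Its nearest neighbour is compound 3, reached by a 6.1-fold higher number from compound 2 to compound 3 (0.78 log units; beyond the scatter), and the furthest is compound 1, separated by an 11-fold lower number from compound 1 to compound 2 (1.04 log units; beyond the scatter). Compound 1 and compound 3 lie close together, the step of a 1.8-fold lower number from compound 1 to compound 3 (0.26 log units; within the scatter) being within the scatter.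

The next compound, compound 4, is `C=C(Br)C(=O)Nc1ccc2c(c1)/C(=C/c1ccsc1)C(=O)N2`. Relative to compound 2 the change is the two compounds have the same atoms and bonds and differ only in configuration as drawn: 1 of 1 stereo elements differ; a double bond is drawn E in compound 2 and Z in compound 4. Going by the values given here, none of the measured steps bears on this kind of change: each of them alters which thiophene ring sits on the double-bonded chain carbon or adds a methyl to that ring, and none alters the drawn geometry of the double bond itself. The two steps that were beyond the scatter, an 11-fold lower number from compound 1 to compound 2 (1.04 log units; beyond the scatter) and a 6.1-fold higher number from compound 2 to compound 3 (0.78 log units; beyond the scatter), therefore give no guidance on size or direction here. In the absence of any comparable step, the working expectation for compound 4 is no step beyond the scatter, with a range wide enough to admit a sizeable move in either direction.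

Compound 4 is therefore expected at 90 nM in this assay, between 25 nM and 400 nM. The expected step from compound 2 is a 1.6-fold higher number from compound 2 to compound 4 (0.21 log units; within the scatter).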

Compound 4, half-maximal inhibitory concentration: 190 nM
Estimate against measurement, compound 4: 2.1-fold (0.32 log units) below, within the range that was stated.
By their numbers in this assay, from the lowest: compound 2; then compounds 4, 3 and 1 (each within the scatter of the next, the first and the last beyond it).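

The drawn geometry of the double bond is a variable in its own right in this assay: with the thiophen-3-yl group held fixed, going from E to Z gives a 3.4-fold higher number from compound 2 to compound 4 (0.53 log units; beyond the scatter). Going by these compounds alone, the earlier steps all changed the thiophene ring or added a methyl to it, so they showed only that the ring on the double-bonded chain carbon matters; this pair shows that the orientation of that same ring also moves the number, with the E form, compound 2, on the lower side. The gap can be assigned to the configuration alone, because nothing else separates the two structures: the fact that compounds 2 and 4 differ only in the configuration as drawn

This is a single E and Z pair, so it remains open whether the same gap, or the same direction, holds for the thiophen-2-yl and 3-methylthiophen-2-yl compounds, and the compounds shown say nothing on why the geometry matters. Also open, going by these compounds, is how a furan-3-yl or pyridin-3-yl ring on the chain carbon, or chlorine in place of the bromine, would behave in either geometry in this assay.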